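From 2-methoxybenzyl to 2,4-dichlorobenzyl: an expected step

A few compounds are considered here, and "the series" means these few. Any claim that something is new, unique, unknown or untested is made for them only; others in the source may bear on it.

Going by the values given here, in a functional assay on HL-60 cells (Homo sapiens) for antiproliferative activity, with a stated time of 72 h (on this read-out lower numbers stand for stronger inhibition and higher numbers for weaker inhibition), compound 2 `COc1ccccc1CNc1ncnc2c1ncn2[C@@H]1O[C@H](CO)[C@@H](O)[C@H]1O` gives 2300 nM, the lower of the two numbers known so far, while compound 1 `OC[C@H]1O[C@@H](n2cnc3c(NCc4cccc(Br)c4)ncnc32)[C@H](O)[C@@H]1O` gives 8000 nM. Among the compounds with values here, only one measured step bears on the next change: a 3.5-fold lower number from compound 1 to compound 2 (0.54 log units; beyond the scatter), a modest step beyond the scatter, with 2-methoxyphenyl in place of 3-bromophenyl on a saturated chain carbon bound to a nitrogen on an aromatic ring. Compound 3 `OC[C@H]1O[C@@H](n2cnc3c(NCc4ccc(Cl)cc4Cl)ncnc32)[C@H](O)[C@@H]1O` changes that same place, with 2,4-dichlorophenyl in place of 2-methoxyphenyl on a saturated chain carbon bound to a nitrogen on an aromatic ring. Its ring carries halogen again, as does that of compound 1 at 8000 nM, so a modest move toward a higher number is expected in this assay, though a single pair is thin evidence. The expected change is a 2.2-fold higher number from compound 2 to compound 3 (0.34 log units; beyond the scatter). Compound 3 is estimated at 5000 nM, with an expected range from 1800 nM to 14000 nM.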

Compound 3, half-maximal inhibitory concentration: 96300 nM
Beside the measured number, compound 3's estimate is 19-fold (1.28 log units) below it; measured number outside the range, above it.
By their numbers in this assay, from the lowest: compound 2; then compound 1; then compound 3.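

In this assay, this place, on a saturated chain carbon bound to a nitrogen on an aromatic ring, proves far more sensitive than the first pair could show: the change to 2,4-dichlorophenyl gives a 42-fold higher number from compound 2 to compound 3 (1.62 log units; beyond the scatter), a large step. Halogen on the ring does not by itself set the number, as 2,4-dichlorophenyl and 3-bromophenyl are far apart, with a 12-fold higher number from compound 1 to compound 3 (1.08 log units; beyond the scatter). Nothing available explains why this change costs so much.

The compounds shown leave open whether the loss follows the chlorine atoms as such or the loss of the methoxy group, and an unsubstituted phenyl ring would be the plain point of reference. Also open, from the compounds shown here alone, is how a longer chain in place of the single saturated carbon, or a pyridine ring in place of the phenyl ring, would read here.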